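Moving the tetrazole one bond further out along the chain

The compounds below may be only part of what the source reports. "The series", "measured", "known", "first", "only" and "open" are said of these compounds alone.

Of the compounds shown here, three built on one shared core have been measured in a functional assay on ileum (Cavia porcellus) with cysteinyl leukotriene receptor (Homo sapiens) as the target; a higher number here means a more potent compound, by a factor of ten per unit of this negative logarithm, a lower number a less potent compound. Compound 1 `CCCc1c(COc2ccc(C(=O)Cc3nnn[nH]3)cc2)ccc(C(C)=O)c1O` gives 7.71. Compound 2 `CCCc1c(COc2ccc(C(=O)CCC(=O)O)cc2)ccc(C(C)=O)c1O` gives 6.75, and compound 3 `CCCc1c(COc2ccc(C(=O)C(C)Cc3nnn[nH]3)cc2)ccc(C(C)=O)c1O` gives 7.18. Among these three numbers compound 3 stands second highest: a number 0.43 log units higher from compound 2 to compound 3 (beyond the scatter), while a number 0.53 log units lower from compound 1 to compound 3 (beyond the scatter), and each of these gaps lies beyond the usual scatter, as does a number 0.96 log units lower from compound 1 to compound 2 (beyond the scatter).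

Compound 4 `CCCc1c(COc2ccc(C(=O)CCCc3nnn[nH]3)cc2)ccc(C(C)=O)c1O` keeps the same atoms as compound 3 but joins them differently: 3-(1H-tetrazol-5-yl)propyl in place of 1-((1H-tetrazol-5-yl)methyl)ethyl on a carbonyl carbon. For the measured compounds named here, no measured step rearranges a chain in quite this way, so the expectation rests on the two steps that touch compound 3. Branching the chain cost a modest amount, since a number 0.53 log units lower from compound 1 to compound 3 (beyond the scatter); compound 4 removes that branch but makes the chain longer. A tetrazole on a branched chain also beat the straight acid chain of compound 2 by a modest margin, as a number 0.43 log units higher from compound 2 to compound 3 (beyond the scatter) shows. Weighing these, a small step is expected in this assay, probably downward but possibly within the scatter, so that a number 0.18 log units lower from compound 3 to compound 4 (within the scatter) is the estimated step. Compound 4 is therefore expected to give about 7, between 6.3 and 7.6.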

Compound 4, negative logarithm of the antagonist equilibrium constant: 7.67
The estimate for compound 4 lay 0.67 log units below the measured number, outside the stated range (above it).
By their numbers in this assay, from the lowest: compound 2; then compound 3; then compounds 4 and 1 (each within the scatter of the next).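

The change from compound 3 to compound 4 moves no atom in or out, yet in this assay it gives a number 0.49 log units higher from compound 3 to compound 4 (beyond the scatter), so at this position the way the chain is joined matters, not only what it contains. Length alone does not account for the lower number of compound 3: 2-(1H-tetrazol-5-yl)ethyl in place of 1H-tetrazol-5-yl on the saturated chain carbon gives a number 0.04 log units lower from compound 1 to compound 4 (within the scatter), which means the unbranched longer chain cannot be told apart from the shorter one, while (1H-tetrazol-5-yl)methyl in place of carboxy gives a number 0.92 log units higher from compound 2 to compound 4 (beyond the scatter). Nothing available explains why these chain changes have these effects.

A 4-(1H-tetrazol-5-yl)butyl group on the same carbonyl carbon would show whether the number holds as the chain grows further, and a 3-carboxypropyl group would compare the acid and the tetrazole on a chain of equal length. On these data alone, it also remains open whether a methyl branch on a different chain carbon would give the same result as the branch in compound 3.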